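The compounds below may be only part of what the source reports. "The series", "measured", "known", "first", "only" and "open" are said of these compounds alone.

Compound 2, with the structure `Cc1ccc(S(=O)(=O)CCO)cc1C#Cc1cc(Cl)ccc1OCC(=O)O`, is the starting point of this step. In an assay on CHO cells for displacement of a labelled ligand from prostaglandin D2 receptor 2 (Homo sapiens), read by scintillation counting (a lower number here means a stronger inhibitor, a higher number a weaker inhibitor), compound 2 gives 19 nM, which is the second highest of the three numbers measured. Its nearest neighbour is compound 1, built as `CCCS(=O)(=O)c1ccc(C)c(C#Cc2cc(C#N)ccc2OCC(=O)O)c1`, which in this assay gives 7 nM, a lower number beyond the usual scatter. Furthest away is compound 3, built as `O=C(O)COc1ccc(Cl)cc1C#Cc1ccccc1`, which in this assay gives 108 nM, a higher number, again beyond the scatter.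

The new compound 4 has the structure `Cc1ccc(S(=O)(=O)NC(C)(C)C)cc1C#Cc1cc(Cl)ccc1OCC(=O)O`. It differs from compound 2 in one place: (tert-butyl)amino in place of 2-hydroxyethyl on a sulfonyl sulfur. The shared core with its acid side chain and chlorine is kept untouched.

For the measured compounds named here, no measured pair in this set shows what such a swap on the sulfonyl sulfur does, so the expectation rests on compound 2 alone. The change is expected to move the number only within the scatter, with the step of a 1.1-fold lower number from compound 2 to compound 4 (0.02 log units; within the scatter) small and without a clear direction. Compound 4 is estimated to give 18 nM in this assay, within a range from 6 nM to 55 nM.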

Compound 4, inhibition constant: 5 nM
For compound 4 the middle estimate is 3.6-fold (0.56 log units) above the measured one; the measured number lies below the stated range.
By their numbers in this assay, from the lowest: compounds 4 and 1 (each within the scatter of the next); then compound 2; then compound 3.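

In this assay, putting (tert-butyl)amino in place of 2-hydroxyethyl on a sulfonyl sulfur brings a 3.8-fold lower number from compound 2 to compound 4 (0.58 log units; beyond the scatter), so what sits on this sulfur does matter to the number. For the compounds shown here, this is the first direct reading at this place, since no earlier pair differed there alone, and it shows that a group of 5 heavy atoms with no oxygen is tolerated in place of one of 3 heavy atoms. Nothing available here explains why the number falls.

Going by these compounds alone, the single step cannot separate the contribution of the nitrogen from that of the tert-butyl, which a plain amino group or a methylamino group would help to do. It also leaves open whether the same swap carries over to the nitrile-bearing core of compound 1.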